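Extending the Sulfonyl Chain of Compound 1

The source may hold more compounds than are shown below. What is called first, only, known or untested is meant among the compounds shown, and "the series" means these compounds.

In a physicochemical assay for lipophilicity (on this read-out lower numbers stand for lower lipophilicity and higher numbers for higher lipophilicity), compound 1 (`CCCCCCS(=O)(=O)c1ccc(O)c(C(=O)Nc2ccc(Br)cc2)c1`) gives 3.2. This lies within the usual scatter of compound 2 (`CCCCS(=O)(=O)c1ccc(O)c(C(=O)Nc2ccc(C(F)(F)F)cc2)c1`) at 3.1, whereas compound 3 (`CCCCCCCCS(=O)(=O)c1ccc(O)c(C(=O)Nc2ccc(C(F)(F)F)cc2)c1`) gives 5.26, and the gap between compound 1 and compound 3 exceeds that scatter. Compound 4 (`CCCCCCCCCCS(=O)(=O)c1ccc(O)c(C(=O)Nc2ccc(Br)cc2)c1`) differs from compound 1 by butyl in place of hydrogen on a saturated chain carbon, six bonds along the chain from a sulfonyl sulfur. Among the compounds with values here, the only measured step of this kind is a number 2.16 log units higher from compound 2 to compound 3 (beyond the scatter). There the same butyl enters four bonds along the chain, and compound 2 and compound 3 carry trifluoromethyl where compound 1 and compound 4 carry bromine. A similarly large upward change is therefore expected in this assay, with an expected step of a number 2.10 log units higher from compound 1 to compound 4 (beyond the scatter). Compound 4 is estimated at 5.3, with an expected range from 4.7 to 6.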

Compound 4, distribution coefficient: 5.36
Beside the measured number, compound 4's estimate is 0.06 log units below it, within the range that was stated.
By their numbers in this assay, from the lowest: compounds 2 and 1 (each within the scatter of the next); then compounds 3 and 4 (each within the scatter of the next).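

In this assay, the same butyl change gives a number 2.16 log units higher from compound 1 to compound 4 (beyond the scatter) and so matches in size a number 2.16 log units higher from compound 2 to compound 3 (beyond the scatter) in the earlier pair. The large rise therefore holds six bonds along the chain from a sulfonyl sulfur as well as four bonds along, and with bromine in place of trifluoromethyl. No evidence is available to explain the size of this step.

The compounds shown leave open whether a longer chain would continue the rise. They also leave open what an amine or a carboxylic acid in place of the butyl would give.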